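The source may hold more compounds than are shown below. What is called first, only, known or untested is meant among the compounds shown, and "the series" means these compounds.

In a functional assay on HL-60 cells (Homo sapiens) for cytotoxicity, read by WST assay, with a stated time of 48 h (a lower number here means that less compound is needed, a higher number that more compound is needed for the effect), compound 1 `CCCCCCCOc1cccc(C[C@H]2C(=O)OC[C@@H]2Cc2ccccc2)c1` gives 81000 nM, compound 2 `COc1ccccc1C[C@H]1COC(=O)[C@@H]1Cc1ccc(Cl)c(Cl)c1` gives 14000 nM, and compound 3 `Oc1ccccc1C[C@H]1COC[C@@H]1Cc1ccc(Cl)c(Cl)c1` gives 34000 nM. Compound 3 therefore stands in the middle of the three, with compound 1 needing more and compound 2 needing less, both gaps beyond the usual scatter. Compound 4 `Oc1ccc(C[C@H]2COC[C@@H]2Cc2ccc(Cl)c(Cl)c2)cc1` has the same atoms as compound 3, joined differently: 4-hydroxyphenyl in place of 2-hydroxyphenyl on a saturated chain carbon bound to a saturated ring carbon. Within the data shown here, no pair of measured compounds shows this change, so the expectation stays anchored on compound 3 at 34000 nM, with no step beyond the scatter expected in this assay. The estimated change is a 1.1-fold lower number from compound 3 to compound 4 (0.05 log units; within the scatter). For compound 4 the expected value is 30000 nM, with an estimated range of 12000 nM to 70000 nM.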

Compound 4, half-maximal effective concentration: 31000 nM
Estimate against measurement, compound 4: 1.0-fold (0.01 log units) below, within the range that was stated.
By their numbers in this assay, from the lowest: compound 2; then compounds 4 and 3 (each within the scatter of the next); then compound 1.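

In this assay, among these compounds, 4-hydroxyphenyl in place of 2-hydroxyphenyl on a saturated chain carbon bound to a saturated ring carbon gives a 1.1-fold lower number from compound 3 to compound 4 (0.04 log units; within the scatter), the first single change that can be read in this set. At this place, the assay therefore does not separate these two hydroxyphenyl groups. Nothing measured here speaks to why this is so. On these data alone, it remains open whether an amine or a carboxylic acid in place of the hydroxy group would move the number in this assay beyond the scatter. The same holds for a longer chain at that place.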